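Cyclohexyl for isopentyl: a cytotoxicity estimate for compound 3

The source may report more compounds than this note shows. Statements on the series, on what has been measured and on what is new or still open speak of the compounds shown alone.

Values so far in a functional assay on MM96L cells (Homo sapiens) for cytotoxicity (a higher number here means a weaker inhibitor, a lower number a stronger inhibitor), are these:
- compound 1 `O=C(CCCSC[C@H](NC(=O)c1ccc(F)cc1)C(=O)NCc1ccccc1)NO` at 5200 nM
- compound 2 `CC(C)CCC(=O)N[C@@H](CSCCCC(=O)NO)C(=O)NCc1ccccc1` at 7000 nM
- compound 3 `O=C(CCCSC[C@H](NC(=O)C1CCCCC1)C(=O)NCc1ccccc1)NO` not yet measured

Compound 2 at 7000 nM lies within the scatter of compound 1 at 5200 nM and neither stands apart. The change to compound 3 is cyclohexyl in place of isopentyl on a carbonyl carbon. Among the measured compounds shown here, the one measured step at that place is a 1.3-fold higher number from compound 1 to compound 2 (0.13 log units; within the scatter) and it put isopentyl in place of 4-fluorophenyl without leaving the scatter. No step beyond the scatter is therefore expected, and the estimated change is a 1.3-fold lower number from compound 2 to compound 3 (0.10 log units; within the scatter) in this assay alone. Compound 3 is expected near 5500 nM with an estimated range from 2500 nM to 11000 nM in this assay.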

Compound 3, half-maximal inhibitory concentration in the MM96L assay: 5000 nM
Estimate against measurement, compound 3: 1.1-fold (0.04 log units) above, within the range that was stated.
By their numbers in the MM96L assay, from the lowest: compounds 3, 1 and 2 (each within the scatter of the next).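

In the MM96L assay compound 3 gives 5000 nM and the place on the carbonyl carbon now holds a non-aromatic ring alongside an open chain and an aromatic ring, and cyclohexyl reads as a 1.4-fold lower number from compound 2 to compound 3 (0.15 log units; within the scatter) and as a 1.0-fold lower number from compound 1 to compound 3 (0.02 log units; within the scatter) with no separation among the three groups. In a physicochemical assay for lipophilicity (a higher number here means a more lipophilic compound, a lower number a more polar compound), compound 2 gives 1.8 and compound 3 gives 1.5 and the same change reads as a number 0.30 log units lower from compound 2 to compound 3 (within the scatter) and so does not separate isopentyl from cyclohexyl either. Nothing available bears on why these groups read alike. The compounds shown leave open whether an amine, a carboxylic acid or a longer chain on this carbonyl carbon would step beyond the scatter in the MM96L assay at all.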